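Swapping methyl for 4-fluorophenyl on a sulfonyl

A few compounds are considered here, and "the series" means these few. Any claim that something is new, unique, unknown or untested is made for them only; others in the source may bear on it.

Measured so far in a functional assay on MDA-MB-231 cells (Homo sapiens) for inhibition, read by sulforhodamine B assay, tested at 10 uM; on this read-out higher numbers stand for more inhibition at the one concentration tested (going by the name of the read-out) and lower numbers for less inhibition:
compound 1 `CC(=O)N1N=C(c2ccc(-n3cncn3)cc2)CC1c1ccc(N(C)C)cc1` gives 7.4%
compound 2 `CN(C)c1ccc(C2CC(c3ccc(-n4cncn4)cc3)=NN2C(=O)c2ccc(C(F)(F)F)cc2)cc1` gives 16.7%
compound 3 `CN(C)c1ccc(C2CC(c3ccc(-n4cncn4)cc3)=NN2S(C)(=O)=O)cc1` gives 7.8%

All three numbers lie within the scatter of one another, so none of them can be called higher or lower than the rest. Compound 3 sits second highest of the three. Compound 4 `CN(C)c1ccc(C2CC(c3ccc(-n4cncn4)cc3)=NN2S(=O)(=O)c2ccc(F)cc2)cc1` differs from compound 3 in one place: 4-fluorophenyl in place of methyl on a sulfonyl sulfur. For the measured compounds named here, the closest precedent is a number 9.3 percentage points higher from compound 1 to compound 2 (within the scatter), where methyl also gave way to a substituted phenyl, though on a carbonyl carbon; that change stayed within the scatter. A similarly small move is therefore expected here, with a number 5.2 percentage points higher from compound 3 to compound 4 (within the scatter) the anticipated step. Compound 4 is estimated at 13%, in a range from 0% to 30%.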

Compound 4, a percentage reported as inhibition, at one concentration (the size of the read-out at that concentration, not a potency): 12.1%
Compound 4: middle estimate off by 0.9 percentage points, on the high side; the range from low to high includes it.
By their numbers in this assay, from the lowest: compounds 1, 3, 4 and 2 (each within the scatter of the next).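

On the sulfonyl sulfur, 4-fluorophenyl can stand in place of methyl without taking the number in this assay outside the usual scatter (a number 4.3 percentage points higher from compound 3 to compound 4 (within the scatter)). The other two new comparisons also stay within the scatter (a number 4.6 percentage points lower from compound 2 to compound 4 (within the scatter); a number 4.7 percentage points higher from compound 1 to compound 4 (within the scatter)), so this read-out does not separate these groups on the ring nitrogen at this one concentration. Nothing measured here offers an explanation for these small steps.

From the compounds shown here alone, whether an amine or carboxylic acid on the sulfonyl sulfur, or a longer chain there, would give a number beyond the scatter remains open.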